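The source may hold more compounds than are shown below. What is called first, only, known or untested is meant among the compounds shown, and "the series" means these compounds.

Measured compounds:
compound 1 `c1coc(CN2CCN(CCCc3c[nH]c4ccc(-n5cnnc5)cc34)CC2)c1` — 18 nM
compound 2 `NC(=O)C(c1ccccc1)N1CCN(CCCc2c[nH]c3ccc(-n4cnnc4)cc23)CC1` — 55 nM; 13 nM (2 entries)
compound 3 `c1ccc(N2CCN(CCCc3c[nH]c4ccc(-n5cnnc5)cc34)CC2)cc1` — 13 nM

In an assay on CHO cells for displacement of a labelled ligand from 5-hydroxytryptamine receptor 1B (Homo sapiens) (on this read-out lower numbers stand for stronger inhibition and higher numbers for weaker inhibition), compound 1 gives 18 nM, which puts it at the upper end of the single numbers shown; its nearest neighbour is compound 3, and the gap, a 1.4-fold lower number from compound 1 to compound 3 (0.14 log units; within the scatter), lies within the scatter. Compound 2 carries several entries, (the several entries of compound 2 in this assay, 55 nM; 13 nM (2 entries)), so it offers no single number to set against the others.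

Compound 4 `c1ccc(CCCN2CCN(CCCc3c[nH]c4ccc(-n5cnnc5)cc34)CC2)cc1` differs from compound 1 by phenethyl in place of furan-2-yl on a saturated chain carbon bound to an amine nitrogen in a ring. Among the measured compounds shown here, the only measured step touching this position is a 1.4-fold lower number from compound 1 to compound 3 (0.14 log units; within the scatter), in which phenyl replaced (furan-2-yl)methyl on the ring amine nitrogen without moving the number beyond the scatter. For the measured compounds named here, no measured step covers a phenethyl group on that chain carbon, so the expectation rests on that one step alone. The step from compound 1 to compound 4 is therefore expected to stay within the scatter, a 1.2-fold lower number from compound 1 to compound 4 (0.08 log units; within the scatter). Compound 4 is estimated at 15 nM, with a range from 5 nM to 45 nM.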

Compound 4, half-maximal inhibitory concentration: 85 nM
Compound 4: middle estimate off by 5.7-fold (0.75 log units), on the low side; the whole stated range lies below it.
By their numbers in this assay, from the lowest: compounds 3 and 1 (each within the scatter of the next); then compound 4.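

The earlier step on the ring amine nitrogen, (furan-2-yl)methyl to phenyl, stayed within the scatter in this assay and gave no sign that this position could shift the number at all. The 3-phenylpropyl group does shift it, with a 4.7-fold higher number from compound 1 to compound 4 (0.67 log units; beyond the scatter) and a 6.5-fold higher number from compound 3 to compound 4 (0.82 log units; beyond the scatter) on the same read-out. So this nitrogen does not accept every group alike, and of the three groups compared here, only 3-phenylpropyl stands apart.

As far as these compounds go, whether a benzyl or a 2-phenylethyl group on this nitrogen would stay with compound 3 or move towards compound 4 remains open, as does whether a 3-(furan-2-yl)propyl group would behave like 3-phenylpropyl. Nothing in what is shown offers a reason for the higher number of compound 4.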